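Swapping the chloro for acetyl(methyl)amino

This account rests on a few compounds, and the source may have more. Where it says the series, first, only, none or still open, it means among the compounds named here.

Of the compounds shown here, two have been measured in a functional assay on HEK293 cells for agonist activity at G-protein coupled receptor 39 (Mus musculus), read by inositol phosphate accumulation; a higher number here means that more compound is needed for the effect, a lower number that less compound is needed. Compound 1 `CNc1nc(NCc2ccc(S(C)(=O)=O)cc2)cc(-c2ccccn2)n1` gives 185 nM, and compound 2 `CNc1nc(NCc2ccc(Cl)cc2)cc(-c2ccccn2)n1` gives 3 nM. Within the data shown here, on these two numbers compound 2 stands at the lowest value, with compound 1 as its only neighbour, and the step from compound 1 to compound 2 a 62-fold lower number from compound 1 to compound 2 (1.79 log units; beyond the scatter) is the single measured change on the same aromatic carbon. Compound 3 `CNc1nc(NCc2ccc(N(C)C(C)=O)cc2)cc(-c2ccccn2)n1` differs from compound 2 in one place: acetyl(methyl)amino in place of chloro on an aromatic carbon. Among the measured compounds shown here, this reverses the direction of the only known step, again replacing chloro with a group of several heavy atoms that carries one hydrogen-bond acceptor, so the expectation in this assay is a higher number for compound 3 than for compound 2, though not necessarily as large as that step. Compound 3 is therefore estimated at 60 nM, within a range of 10 nM to 400 nM, which means an expected step of a 20-fold higher number from compound 2 to compound 3 (1.30 log units; beyond the scatter).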

Compound 3, half-maximal effective concentration: 2610 nM
Estimate against measurement, compound 3: 44-fold (1.64 log units) below, and the stated range ends below it.
By their numbers in this assay, from the lowest: compound 2; then compound 1; then compound 3.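

In this assay, the change to acetyl(methyl)amino brings an 870-fold higher number from compound 2 to compound 3 (2.94 log units; beyond the scatter), the largest step among these three compounds, so this aromatic carbon is very sensitive to which group it carries. Compound 1 also turns out not to mark the high end of the range: acetyl(methyl)amino in place of methylsulfonyl gives a 14-fold higher number from compound 1 to compound 3 (1.15 log units; beyond the scatter), so these two groups are far from interchangeable here, even though neither matches chloro. Nothing available explains why these steps are so large.

Still open, going by these compounds, is whether fluoro, methyl or a simple amine at this carbon would stay close to chloro, or whether chloro is unusually favourable. On these data alone, it is also open whether acetylamino, which lacks the methyl on the nitrogen, would recover any of the lost ground.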